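The compounds below may be only part of what the source reports. "The series", "measured", "known", "first", "only" and "open" are said of these compounds alone.

Within the data shown here, in a functional assay on MDA-MB-231 cells (Homo sapiens) for inhibition, read by MTT assay, with a stated time of 72 h (a lower number here means a stronger inhibitor, a higher number a weaker inhibitor), compound 1 `Nc1nc2cc(-c3nn(CCCCC(=O)NO)c4ncnc(N)c34)ccc2o1` gives 21200 nM, the only actual number so far. Compound 2 `Nc1ncnc2c1c(-c1cnc3[nH]ccc3c1)nn2CCC(=O)NO` has no number in this assay, only a limit: > 150000 nM. Compound 3 `Nc1nc2cc(-c3nn(CCCCCCC(=O)NO)c4ncnc(N)c34)ccc2o1` keeps the core of compound 1 and changes by 2-(hydroxycarbamoyl)ethyl in place of hydroxycarbamoyl on a saturated chain carbon, four bonds along the chain from an aromatic nitrogen. Among the measured compounds shown here, no measured pair isolates this change, so the expected step of a 7.1-fold lower number from compound 1 to compound 3 (0.85 log units; beyond the scatter) is a tentative estimate, toward stronger inhibition and beyond the usual scatter. For compound 3 the expected value in this assay is 3000 nM, with an estimated range from 400 nM to 15000 nM.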

Compound 3, half-maximal inhibitory concentration: 8430 nM
The estimate for compound 3 lay 2.8-fold (0.45 log units) below the measured number; the measured number falls inside the stated range.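

Among these compounds, this is the first pair that differs in one place, and lengthening the chain that ends in hydroxycarbamoyl gives, in this assay, a 2.5-fold lower number from compound 1 to compound 3 (0.40 log units; beyond the scatter), a modest move toward stronger inhibition. Chain length alone therefore changes the number at this position, although a single step cannot define a trend. Nothing shown here accounts for the step. On these data alone, it remains open whether a longer chain would lower the number further. As far as these compounds go, it is also open whether an amine or a carboxylic acid could replace the hydroxycarbamoyl end and retain inhibition.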